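A few compounds are considered here, and "the series" means these few. Any claim that something is new, unique, unknown or untested is made for them only; others in the source may bear on it.

In a functional assay on MOLT-4 cells (Homo sapiens) for antiproliferative activity, read by MTT assay, with a stated time of 48 h (a higher number here means a weaker inhibitor, a lower number a stronger inhibitor), three compounds have been measured so far. Compound 1 `O=C(/C=C/c1ccc(Cn2cc(Nc3ncc(Cl)c(Nc4ccc(F)cc4)n3)cn2)cc1)NO` gives 330 nM, compound 2 `COc1ccc(Nc2nc(Nc3cnn(CCCCCCC(=O)NO)c3)ncc2Cl)cc1` gives 170 nM, and compound 3 `O=C(CCCCCn1cc(Nc2ncc(Cl)c(Nc3cccc(Cl)c3)n2)cn1)NO` gives 80 nM. Compound 2 thus lies within the usual scatter of compound 1, and it is a weaker inhibitor than compound 3 by a gap just beyond that scatter. The unmeasured compound 4 `O=C(CCCCCCn1cc(Nc2ncc(Cl)c(Nc3ccccc3)n2)cn1)NO` differs from compound 2 in one place, with hydrogen in place of methoxy on an aromatic carbon, para to a large group, turning 4-methoxyphenyl into phenyl: hydrogen in place of methoxy on an aromatic carbon. Among the compounds with values here, no two measured compounds differ in one place alone, so the data do not isolate this change. Compound 1 at 330 nM and compound 3 at 80 nM also carry no methoxy, and their values point in no single direction. In this assay, the estimated 1.3-fold lower number from compound 2 to compound 4 (0.12 log units; within the scatter) is expected to stay within the scatter. The value expected for compound 4 is 130 nM, with an estimated range of 50 nM to 330 nM.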

Compound 4, half-maximal inhibitory concentration: 160 nM
For compound 4 the middle estimate is 1.2-fold (0.09 log units) below the measured one; measured number inside the range.
By their numbers in this assay, from the lowest: compounds 3, 4, 2 and 1 (each within the scatter of the next, the first and the last beyond it).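

In this assay, hydrogen in place of methoxy on an aromatic carbon, para to a large group, gives a 1.1-fold lower number from compound 2 to compound 4 (0.03 log units; within the scatter). Within the data shown here, this is the first single change that can be read on its own, and it shows that turning 4-methoxyphenyl into phenyl leaves the number within the scatter in this pair. The finding rests on this one pair and on this one position of the ring. Nothing available bears on why the number holds when the methoxy group leaves.

The compounds shown leave open whether an amine or a carboxylic acid on the same carbon would also leave the number within the scatter. They also leave open what a longer chain in place of methoxy, such as butoxy, would do.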